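This account rests on a few compounds, and the source may have more. Where it says the series, first, only, none or still open, it means among the compounds named here.

Measured in a functional assay on Huh-7 cells (Homo sapiens) for antiproliferative activity, read by sulforhodamine B assay, with a stated time of 72 h; a lower number here means a stronger inhibitor, a higher number a weaker inhibitor:
- compound 1 `Cc1ccc(COc2ccc(-c3cc(CN4CCN(Cc5ccc(C(F)(F)F)cc5)CC4)no3)cc2)cc1`: 1500 nM
- compound 2 `FC(F)(F)c1ccc(CN2CCN(Cc3cc(-c4ccc(OCc5cccc(Cl)c5)cc4)on3)CC2)cc1`: 200 nM
- compound 3 `FC(F)(F)c1ccc(CN2CCN(Cc3cc(-c4ccc(OCc5ccc(Cl)cc5)cc4)on3)CC2)cc1`: 4000 nM

Compound 3 gives the highest number of the three: a 2.7-fold higher number from compound 1 to compound 3 (0.43 log units; beyond the scatter), and a 20-fold higher number from compound 2 to compound 3 (1.30 log units; beyond the scatter). The next step leads to compound 4 `N#Cc1cccc(COc2ccc(-c3cc(CN4CCN(Cc5ccc(C(F)(F)F)cc5)CC4)no3)cc2)c1`, not yet measured: 3-cyanophenyl in place of 4-chlorophenyl on a saturated chain carbon bound to an oxygen on an aromatic ring.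

Two of the measured steps bear on this change, since both alter the benzyl ether at the same place. a 20-fold higher number from compound 2 to compound 3 (1.30 log units; beyond the scatter) is the closest: it moves a chloro from the 3-chlorophenyl to the 4-chlorophenyl and the number rises sharply. a 7.5-fold lower number from compound 1 to compound 2 (0.88 log units; beyond the scatter) points the same way, the 3-chlorophenyl giving the lower number than the 4-methylphenyl. Compound 4 returns to a 3-substituted benzyl ether, as in compound 2. Nothing measured covers a nitrile in place of a chloro on that ring, so the size is uncertain, but a lower number in this assay is expected, an 8.0-fold lower number from compound 3 to compound 4 (0.90 log units; beyond the scatter). For compound 4 the estimate is 500 nM, within 120 nM to 2500 nM.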

Compound 4, half-maximal inhibitory concentration: 100 nM
The estimate for compound 4 lay 5.0-fold (0.70 log units) above the measured number; measured number below the stated range.
By their numbers in this assay, from the lowest: compounds 4 and 2 (each within the scatter of the next); then compound 1; then compound 3.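

In this assay, 3-cyanophenyl in place of 4-chlorophenyl on the saturated chain carbon bound to an oxygen gives a 40-fold lower number from compound 3 to compound 4 (1.60 log units; beyond the scatter), and in place of 4-methylphenyl it gives a 15-fold lower number from compound 1 to compound 4 (1.18 log units; beyond the scatter), so a low number at this place does not depend on a chloro. The nitrile and the chloro on the 3-substituted ring cannot be told apart, with a 2.0-fold lower number from compound 2 to compound 4 (0.30 log units; within the scatter), and among these compounds both 3-substituted rings give lower numbers than both 4-substituted rings, with no compound going against this. No evidence at hand gives a reason for this result.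

Still open, on these data alone, is how much of the large steps comes from where the substituent sits and how much from which substituent it is: a 4-cyanophenyl and a 3-methylphenyl at this place would separate the two. Also open, as far as these compounds go, is how an unsubstituted phenyl or a 3-carboxyphenyl would read here.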